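Hydroxy-to-hydrogen swap on the second ring of a diarylheptanoid pair

The compounds below may be only part of what the source reports. "The series", "measured", "known", "first", "only" and "open" are said of these compounds alone.

Three compounds of the series carry numbers in a physicochemical assay for solubility, using the shake flask method, with a stated time of 12 h; a higher number here means a more soluble compound, a lower number a less soluble compound. Compound 1 `O=C(/C=C/c1ccc(O)c(O)c1)CC(=O)/C=C/c1cccc(O)c1O` gives 3800 nM, compound 2 `O=C(/C=C/c1ccc(O)cc1)CC(=O)/C=C/c1cccc(O)c1O` gives 4800 nM, and compound 3 `O=C(/C=C/c1cc(O)ccc1O)CC(=O)/C=C/c1cccc(O)c1O` gives 100000 nM, the highest of the three. The change from compound 1 to compound 2 is hydrogen in place of hydroxy on an aromatic carbon; it made a 1.3-fold higher number from compound 1 to compound 2 (0.10 log units; within the scatter). The cores of compound 1 and compound 3 differ in 2,5-dihydroxyphenyl in place of 3,4-dihydroxyphenyl on a double-bonded chain carbon bound to a double-bonded chain carbon, which made a 26-fold higher number from compound 1 to compound 3 (1.42 log units; beyond the scatter), while compound 2 against compound 3 shows a 21-fold higher number from compound 2 to compound 3 (1.32 log units; beyond the scatter).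

Compound 4 `O=C(/C=C/c1ccccc1O)CC(=O)/C=C/c1cc(O)ccc1O` is not yet measured in this assay. It differs from compound 3 by hydrogen in place of hydroxy on an aromatic carbon. The place of this change reads the same, word for word, as the place of the change from compound 1 to compound 2, so it is taken as the same change, set this time on the core of compound 3 rather than on the core of compound 1. Within the data shown here, the only step available for this change is the one from compound 1 to compound 2, which stayed within the scatter, so the expected step from compound 3 to compound 4 is also small, a 1.1-fold higher number from compound 3 to compound 4 (0.04 log units; within the scatter), because a 1.3-fold higher number from compound 1 to compound 2 (0.10 log units; within the scatter). Whether the same small step holds on the core of compound 3 is not shown by any other pair here; the spread is set wide for that reason. Compound 4 is accordingly estimated at 110000 nM, between 40000 nM and 300000 nM.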

Compound 4, solubility: 4400 nM
Estimate against measurement, compound 4: 25-fold (1.40 log units) above; measured number outside the range, below it.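

In this assay, hydrogen in place of hydroxy did not carry over from one core to the other: a 1.3-fold higher number from compound 1 to compound 2 (0.10 log units; within the scatter), whereas a 23-fold lower number from compound 3 to compound 4 (1.36 log units; beyond the scatter), a large step for the change that here reads 2,3-dihydroxyphenyl to 2-hydroxyphenyl. Among these compounds, the small step on the core of compound 1 therefore gave no guide to the step on the core of compound 3, though this does not show which structural feature separates the two results, and each result rests on a single pair. Nothing measured here accounts for the gap between the two steps.

Still open, on these data alone, is whether the large step on the core of compound 3 belongs to the loss of this hydroxy specifically or would also appear with another group in the same place, such as methoxy, an amine or a carboxylic acid. Also open, as far as these compounds go, is whether the same hydrogen-for-hydroxy change at the other hydroxy positions of compound 3 would give a large step or one within the scatter in this assay.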